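A few compounds are considered here, and "the series" means these few. Any claim that something is new, unique, unknown or untested is made for them only; others in the source may bear on it.

Measured so far:
- compound 1, `COCCOc1cc2oc(=O)n(CCC(=O)O)c2cc1Cl`: 31.6 nM
- compound 2, `O=C(O)CCn1c(=O)oc2cc(OCC3CC3)c(Cl)cc21`: 10 nM

In an assay for inhibition of kynurenine 3-monooxygenase (Homo sapiens), read by mass spectrometry, with a stated time of 1 h (a higher number here means a weaker inhibitor, a lower number a stronger inhibitor), compound 2 gives 10 nM, the lowest of the two numbers shown; its nearest neighbour is compound 1, with 31.6 nM. For the measured compounds named here, the single measured step, a 3.2-fold lower number from compound 1 to compound 2 (0.50 log units; beyond the scatter), rewards the cyclopropyl on a saturated chain carbon bound to an oxygen on an aromatic ring over methoxymethyl.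

Compound 3, `COc1cc2oc(=O)n(CCC(=O)O)c2cc1Cl`, is not yet measured. Its change from compound 2 is hydrogen in place of cyclopropyl on a saturated chain carbon bound to an oxygen on an aromatic ring. Going by the values given here, that step bears on the one known step only loosely: it removes the cyclopropyl that the step from compound 1 to compound 2 brought in, leaving a methoxy rather than returning to methoxymethyl. A modest rise in the number is therefore expected, of roughly the size of that step, estimated at a 3.5-fold higher number from compound 2 to compound 3 (0.54 log units; beyond the scatter). Compound 3 is expected to give 35 nM, within 12 nM to 110 nM.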

Compound 3, half-maximal inhibitory concentration in the kynurenine 3-monooxygenase assay: 12.6 nM
Compound 3: the middle estimate sits 2.8-fold (0.44 log units) above what was measured, and the stated range covers the measured number.
By their numbers in the kynurenine 3-monooxygenase assay, from the lowest: compounds 2 and 3 (each within the scatter of the next); then compound 1.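

In the kynurenine 3-monooxygenase assay compound 3 gives 12.6 nM, so the cyclopropyl proves dispensable at this position, with a 1.3-fold higher number from compound 2 to compound 3 (0.10 log units; within the scatter), whereas hydrogen in place of methoxymethyl gives a 2.5-fold lower number from compound 1 to compound 3 (0.40 log units; beyond the scatter). Among these three compounds, then, a longer group on this carbon does not track with the number: it is the methoxymethyl of compound 1 that stands apart, while cyclopropylmethoxy and methoxy cannot be told apart. In a physicochemical assay for permeability, using PAMPA (a higher number here means that the compound crosses the layer faster, a lower number that the compound crosses the layer more slowly), compound 2 gives 19 nm/s, and the same change does register, with an at least 6.3-fold lower number from compound 2 to compound 3 (0.80 log units; beyond the scatter). In the physicochemical assay compound 3 gives < 3 nm/s, which is a limit, not a number: the limit of < 3 nm/s in the physicochemical assay, at which 1 of the 2 values shown sits.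

The compounds leave open how a longer chain or an amine on this oxygen would fall in either assay. Nor do they show what an amide in place of the carboxylic acid would do.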